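The source may report more compounds than this note shows. Statements on the series, on what has been measured and on what is new or still open speak of the compounds shown alone.

Compound 1 `Cc1cccc(Cn2ccc3nc(-c4ccccc4)nc-3c2)c1`: > 100000 nM
Compound 2 `Brc1ccccc1Cn1ccc2nc(-c3ccccc3)nc-2c1`: > 100000 nM

In an ADME assay on MDBK cells (Bos taurus) for cytotoxicity (a lower number here means that less compound is tolerated, a higher number that more compound is tolerated), compound 2 gives > 100000 nM, which is a limit of the assay and not a number. Compound 1 gives > 100000 nM, also a limit. Among the measured compounds shown here, the only measured step, a step that the two limits leave unreadable from compound 1 to compound 2, therefore has no readable size, and the evidence amounts to the limit of > 100000 nM in this assay, at which 2 of the 2 values shown sit. Compound 3 `Brc1ccc(Cn2ccc3nc(-c4ccccc4)nc-3c2)cc1` carries 4-bromophenyl in place of 2-bromophenyl on a saturated chain carbon bound to an aromatic nitrogen. With no readable step to suggest otherwise, no change beyond the scatter is expected, an estimated a number no higher from compound 2 to compound 3 (the limit leaves the size open). Compound 3 is expected at 100000 nM, with an estimated range of 50000 nM to 100000 nM.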

Compound 3, half-maximal cytotoxic concentration: 83000 nM
Compound 3: middle estimate off by 1.2-fold (0.08 log units), on the high side; measured number inside the range.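

Among the compounds shown here, compound 3 is the first compound here to give a number and not a limit, so this place, on a saturated chain carbon bound to an aromatic nitrogen, now has one readable value. In this assay, 4-bromophenyl in place of 2-bromophenyl gives an at least 1.2-fold lower number from compound 2 to compound 3 (0.08 log units; that floor lies within the scatter), and 4-bromophenyl in place of 3-methylphenyl gives an at least 1.2-fold lower number from compound 1 to compound 3 (0.08 log units; that floor lies within the scatter). Going by these compounds, neither step alone establishes a real difference, and their true sizes remain open. On these data alone, what an amine, a carboxylic acid or a longer chain at this place would do in this assay also stays open.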